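The source may hold more compounds than are shown below. What is called first, only, known or untested is meant among the compounds shown, and "the series" means these compounds.

Measured so far in a functional assay on Raji cells (Homo sapiens) for antiproliferative activity, read by MTT assay, with a stated time of 72 h; on this read-out higher numbers stand for weaker inhibition and lower numbers for stronger inhibition:
- compound 1 `CN(Cc1nc(C2CCN(Cc3ccccc3)CC2)no1)c1ncc(C(=O)NO)cn1` gives 27.6 nM
- compound 2 `CN(Cc1nc(C2CCN(Cc3ccccc3F)CC2)no1)c1ncc(C(=O)NO)cn1` gives 98.6 nM

Compound 1 holds the lower of these two numbers, which makes it the stronger inhibitor of the pair. Compound 3 `CN(Cc1nc(C2CCN(Cc3ccc(C(F)(F)F)cc3)CC2)no1)c1ncc(C(=O)NO)cn1` keeps the core of compound 1 but carries trifluoromethyl in place of hydrogen on an aromatic carbon, turning benzyl into 4-(trifluoromethyl)benzyl (trifluoromethyl in place of hydrogen on an aromatic carbon). The closest measured change is fluoro in place of hydrogen on an aromatic carbon, which gave a 3.6-fold higher number from compound 1 to compound 2 (0.55 log units; beyond the scatter) and counts as modest. With that single precedent, a similar rise is expected in this assay, though one step is thin evidence. The expected step is a 2.5-fold higher number from compound 1 to compound 3 (0.40 log units; beyond the scatter) and remains uncertain. Compound 3 is estimated at 70 nM, with an expected range from 20 nM to 250 nM.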

Compound 3, half-maximal inhibitory concentration: 207 nM
Compound 3: middle estimate off by 3.0-fold (0.47 log units), on the low side; the range from low to high includes it.
By their numbers in this assay, from the lowest: compound 1; then compound 2; then compound 3.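

In this assay, turning benzyl into 4-(trifluoromethyl)benzyl gives a 7.5-fold higher number from compound 1 to compound 3 (0.88 log units; beyond the scatter) and shows that a second kind of group on this aromatic ring also weakens inhibition. The step from the fluoro compound, a 2.1-fold higher number from compound 2 to compound 3 (0.32 log units; beyond the scatter), adds that the loss depends on what is attached or where, but both the group and its place change in that step, so the two cannot be separated. Going by these compounds, how methoxy or an amine would read at the trifluoromethyl place remains open. No measurement given here explains these rises.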